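The compounds below may be only part of what the source reports. "The series", "measured", "known", "first", "only" and "open" are said of these compounds alone.

Among the compounds with values here, compound 2 `CC1(C)[C@H]2CC[C@]1(C)N(Cc1cn(-c3ccccc3C#N)nn1)C(=O)C2` is one of only two compounds tested so far in a functional assay on PANC-1 cells (Homo sapiens) for inhibition, read by MTT assay, with a stated time of 24 h; a higher number here means a weaker inhibitor, a lower number a stronger inhibitor. In this assay compound 2 gives 240 nM, while compound 1 `CC1(C)[C@H]2CC[C@]1(C)N(Cc1cn(-c3ccc(C#N)cc3)nn1)C(=O)C2` gives 250 nM. The step of a 1.0-fold lower number from compound 1 to compound 2 (0.02 log units; within the scatter), which exchanged 4-cyanophenyl for 2-cyanophenyl, lies within the scatter. Compound 3 `CC1(C)[C@H]2CC[C@]1(C)N(Cc1cn(-c3cccc(Br)c3)nn1)C(=O)C2` differs from compound 2 in one place: 3-bromophenyl in place of 2-cyanophenyl on an aromatic nitrogen. Within the data shown here, no measured step replaces a nitrile with a bromine, and the single measured step gave no change beyond the scatter, so the step of a 1.3-fold higher number from compound 2 to compound 3 (0.10 log units; within the scatter) is expected to be small. Compound 3 is therefore estimated at 300 nM, with a likely range from 120 nM to 900 nM.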

Compound 3, half-maximal inhibitory concentration: 90 nM
Compound 3: the middle estimate sits 3.3-fold (0.52 log units) above what was measured; the measured number lies below the stated range.
By their numbers in this assay, from the lowest: compound 3; then compounds 2 and 1 (each within the scatter of the next).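

The group on this aromatic nitrogen can change the result in this assay: 3-bromophenyl in place of 2-cyanophenyl gives a 2.7-fold lower number from compound 2 to compound 3 (0.43 log units; beyond the scatter) and in place of 4-cyanophenyl gives a 2.8-fold lower number from compound 1 to compound 3 (0.44 log units; beyond the scatter), although exchanging the two cyanophenyl groups gave no change beyond the scatter. Each of these steps changes both the substituent and its place on the phenyl ring, so the two changes cannot be separated. No data here explain the lower number. From the compounds shown here alone, whether the bromine itself matters stays open, as does what a chlorine, a methyl or an amine on that phenyl ring would give.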